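The source may hold more compounds than are shown below. What is called first, only, known or untested is meant among the compounds shown, and "the series" means these compounds.

Measured so far: compound 1 `Cc1nc(N(C)C(=O)NC(=O)c2c(F)cccc2F)sc1C(=O)N/N=C/c1ccc(C(F)(F)F)cc1` and compound 2 `Cc1nc(N(C)C(=O)NC(=O)c2c(F)cccc2F)sc1C(=O)N/N=C/c1cccc(C(F)(F)F)c1`.

In a functional assay on HepG2 cells (Homo sapiens) for inhibition, read by MTT assay, with a stated time of 72 h (on this read-out higher numbers stand for weaker inhibition and lower numbers for stronger inhibition), compound 1 gives only a limit, > 100 ug/mL. In this assay compound 2 gives 31.6 ug/mL, the only number shown. Among the measured compounds shown here, the step of an at least 3.1-fold lower number from compound 1 to compound 2 (0.50 log units; beyond the scatter) is the sole measured comparison. Compound 3 `COc1cc(/C=N/NC(=O)c2sc(N(C)C(=O)NC(=O)c3c(F)cccc3F)nc2C)cc(OC)c1OC` differs from compound 2 by 3,4,5-trimethoxyphenyl in place of 3-(trifluoromethyl)phenyl on a carbon with a double bond to nitrogen. For the measured compounds named here, no measured step concerns this change, so the expected step of a 1.1-fold higher number from compound 2 to compound 3 (0.04 log units; within the scatter) is estimated as none beyond the scatter. Compound 3 is thus expected to give about 35 ug/mL in this assay, estimated between 10 ug/mL and 100 ug/mL.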

Compound 3, half-maximal inhibitory concentration: > 100 ug/mL
Compound 3 ended at the assay's limit (the forecaster's own chance of this, stated with the estimate: 30%); middle value at least 2.8-fold (0.45 log units) from the limit.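

In this assay, 3,4,5-trimethoxyphenyl in place of 3-(trifluoromethyl)phenyl on a carbon with a double bond to nitrogen gives an at least 3.1-fold higher number from compound 2 to compound 3 (0.50 log units; beyond the scatter), so inhibition here is lost with a different ring substitution as well as with 4-(trifluoromethyl)phenyl. Among these three compounds, only compound 2 gives a number rather than a limit. The step between compound 1 and compound 3 cannot be read, since both values are limits: the limit of > 100 ug/mL in this assay, at which 2 of the 3 values shown sit.

As far as these compounds go, how far compound 3 lies past its limit stays open. Also open, from the compounds shown here alone, is whether a phenyl ring with a single methoxy group, or with chlorine, would retain the inhibition of compound 2.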